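This account rests on a few compounds, and the source may have more. Where it says the series, first, only, none or still open, it means among the compounds named here.

- compound 1 `COc1cc(-c2cc(=O)oc3cc(OC)c(OC)c(OC)c23)ccc1O`: 54000 nM
- compound 2 `COc1cc(-c2cc(=O)oc3cc(OC)c(OC)c(OC)c23)cc(OC)c1O`: 62000 nM
- compound 3 `COc1cc(OC)c2c(-c3ccc(O)c(OC)c3)cc(=O)oc2c1`: not yet measured

In a functional assay on CCRF-CEM cells (Homo sapiens) for inhibition (a higher number here means a weaker inhibitor, a lower number a stronger inhibitor), compound 1 gives 54000 nM, and compound 2 lies within the scatter of it at 62000 nM. Compound 3 has hydrogen in place of methoxy on an aromatic carbon of compound 1 (hydrogen in place of methoxy on an aromatic carbon). Among the measured compounds shown here, the only measured step exchanging these two groups, a 1.1-fold higher number from compound 1 to compound 2 (0.06 log units; within the scatter), runs the opposite way on another aromatic carbon, so it is indirect evidence. No change beyond the scatter is therefore expected, and the estimated step is a 1.1-fold lower number from compound 1 to compound 3 (0.03 log units; within the scatter). Compound 3 is expected at 50000 nM, with an estimated range of 20000 nM to 100000 nM.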

Compound 3, half-maximal inhibitory concentration: 10600 nM
Compound 3: middle estimate off by 4.7-fold (0.67 log units), on the high side; measured number below the stated range.
By their numbers in this assay, from the lowest: compound 3; then compounds 1 and 2 (each within the scatter of the next).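

In this assay, this carbon, ortho to two methoxy groups, responds to the exchange: hydrogen in place of methoxy gives a 5.1-fold lower number from compound 1 to compound 3 (0.71 log units; beyond the scatter) and a clear gain in inhibition. A methoxy change on another aromatic carbon gave only a 1.1-fold higher number from compound 1 to compound 2 (0.06 log units; within the scatter) and stayed within the scatter, so the same group does not count equally at every carbon of these compounds. Nothing measured here explains this difference.

From the compounds shown here alone, whether fluorine, an amine or ethoxy at this carbon would behave like hydrogen or like methoxy remains open. So does whether removing either of the two neighbouring methoxy groups would change inhibition.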